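Trading a dichloro-methyl ring for a chloro-ethyl ring

The source may hold more compounds than are shown below. What is called first, only, known or untested is meant among the compounds shown, and "the series" means these compounds.

Compound 1, `Cc1ccc(Nc2nc(N)nc(COc3ccc4c(C)cc(=O)oc4c3)n2)cc1`: in an assay on COS-7 cells for agonist activity at Free fatty acid receptor 1 (Homo sapiens), read by scintillation counting and inositol phosphate accumulation, with a stated time of 90 min (on this read-out lower numbers stand for an effect already at smaller amounts and higher numbers for an effect only at larger amounts of compound), compound 1 gives 1790 nM.
Compound 2, `Cc1ccc(Nc2nc(N)nc(COc3ccc4c(C)cc(=O)oc4c3)n2)cc1Cl`: in this assay compound 2 gives 140 nM.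
Compound 3, `Cc1c(Cl)cc(Nc2nc(N)nc(COc3ccc4c(C)cc(=O)oc4c3)n2)cc1Cl`: in this assay compound 3 gives 600 nM.

Compound 3 stands second highest of the three numbers, sitting between the others with a 3.0-fold lower number from compound 1 to compound 3 (0.47 log units; beyond the scatter) and a 4.3-fold higher number from compound 2 to compound 3 (0.63 log units; beyond the scatter). Compound 4, `CCc1ccc(Nc2nc(N)nc(COc3ccc4c(C)cc(=O)oc4c3)n2)cc1Cl`, has not been measured; it differs from compound 3 by 3-chloro-4-ethylphenyl in place of 3,5-dichloro-4-methylphenyl on a nitrogen on an aromatic ring. Among the measured compounds shown here, two measured steps bear on this change. The first chloro in place of hydrogen gave a 13-fold lower number from compound 1 to compound 2 (1.11 log units; beyond the scatter), while the second chloro gave a 4.3-fold higher number from compound 2 to compound 3 (0.63 log units; beyond the scatter). The change to compound 4 takes one chloro away again, which by itself points back toward the number of compound 2, whereas the ethyl in place of methyl has no measured counterpart among these compounds, so its contribution is unknown. On this basis compound 4 is expected to show a modest step to a lower number, a 2.7-fold lower number from compound 3 to compound 4 (0.44 log units; beyond the scatter), with the uncertainty widened by the untested ethyl. Compound 4 is estimated at 220 nM, within a range of 60 nM to 800 nM.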

Compound 4, half-maximal effective concentration: 160 nM
Compound 4: the middle estimate sits 1.4-fold (0.14 log units) above what was measured; low and high end bracket the measured number.
By their numbers in this assay, from the lowest: compounds 2 and 4 (each within the scatter of the next); then compound 3; then compound 1.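

The ethyl chain, new at this position, is accepted: adding a methyl on the chain carbon leaves compound 2 and compound 4 indistinguishable (a 1.1-fold higher number from compound 2 to compound 4 (0.06 log units; within the scatter)). Exchanging the 3,5-dichloro-4-methylphenyl for the 3-chloro-4-ethylphenyl on the nitrogen gives a step (a 3.8-fold lower number from compound 3 to compound 4 (0.57 log units; beyond the scatter)) that resembles the earlier second-chloro step in reverse (a 4.3-fold higher number from compound 2 to compound 3 (0.63 log units; beyond the scatter)), so one chloro fewer and one chain carbon more together restore the lower number. The large gain from the 4-methylphenyl also survives the longer chain (an 11-fold lower number from compound 1 to compound 4 (1.05 log units; beyond the scatter)).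

Nothing in the available data explains why these groups give these numbers. Still open, as far as these compounds go, is whether a propyl chain, a methoxy group or an amine in place of the ethyl would hold the number, and whether ethyl would behave the same with both chloro groups present.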